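The source may report more compounds than this note shows. Statements on the series, on what has been measured and on what is new or still open speak of the compounds shown alone.

Working notes on the series. Compound 1 `N/C(=N\NC(=S)N1CCCCCC1)c1ccccn1` carries a seven-membered saturated ring on the thiosemicarbazide part; compound 3 `N/C(=N\NC(=S)N1CCSCC1)c1ccccn1` carries a six-membered ring with a sulfur in place of it. How these two cores differ is not broken down here. In a functional assay on A-375 cells (Homo sapiens) for cytotoxicity, read by MTT assay, with a stated time of 72 h, tested at 30 uM (on this read-out higher numbers stand for more inhibition of growth at the one concentration tested and lower numbers for less inhibition of growth), compound 1 gives 90%, and compound 3 gives 86%; the two numbers lie within the scatter of each other.

Compound 2 `Cc1ccnc(/C(N)=N/NC(=S)N2CCSCC2)c1` arises from compound 3 by the change (methyl in place of hydrogen on an aromatic carbon). The step of a number 1.1 percentage points lower from compound 3 to compound 2 (within the scatter) is within the scatter, so compound 2 at 84.9% is indistinguishable from compound 3 in this assay.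

The same change, (methyl in place of hydrogen on an aromatic carbon), leads from compound 1 to the unmeasured compound 4 `Cc1ccnc(/C(N)=N/NC(=S)N2CCCCCC2)c1`. Both "place" descriptions agree word for word, so this is the same change made on the two cores. Since it left the read-out of compound 3 unchanged within the scatter, a step of about a number 1 percentage points lower from compound 1 to compound 4 (within the scatter) is expected for compound 4, resting on that single precedent and on the value of compound 1 at 90%. Compound 4 is accordingly estimated at 89%, with a range of 80% to 96%.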

Compound 4, percent growth inhibition at one concentration: 76.5%
For compound 4 the middle estimate is 12.5 percentage points above the measured one; the whole stated range lies above it.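

On the core of compound 1, methyl in place of hydrogen on an aromatic carbon gives a number 13.5 percentage points lower from compound 1 to compound 4 (beyond the scatter) in this assay, while the same change on the core of compound 3 gives a number 1.1 percentage points lower from compound 3 to compound 2 (within the scatter). Set side by side, these two steps cannot be told apart: the same change on two cores in this assay, a number 1.1 percentage points lower (within the scatter) from compound 3 to compound 2 and a number 13.5 percentage points lower (beyond the scatter) from compound 1 to compound 4, 12.4 percentage points apart, within the scatter of two such steps. For the compounds shown here, the pair therefore does not show that the two cores respond differently to this change, nor does it show that the change carries over unaltered, since each core supplies only one step at the one concentration tested, and one of those steps lies beyond the scatter while the other lies within it.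

Open, on these data alone, is whether a larger group such as ethyl, or a methoxy group, a chlorine or an amine, on the same aromatic carbon opposite the ring nitrogen, would give steps that match on the two cores. Also open, as far as these compounds go, is whether a further pair of cores carrying the same methyl would show a clearer difference between steps.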